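Trading an aromatic ring for a hydroxyethyl chain

This account rests on a few compounds, and the source may have more. Where it says the series, first, only, none or still open, it means among the compounds named here.

Compound 1, `O=C1O[C@H]([C@@H](O)Cn2cc(-c3cccc(O)c3)nn2)C(OCc2ccccc2)=C1OCc1ccccc1`, gives 59900 nM in a functional assay on A549 cells (Homo sapiens) for antiproliferative activity, read by MTT assay, with a stated time of 72 h; a lower number here means a stronger inhibitor, a higher number a weaker inhibitor.
Compound 2, `COc1ccc(-c2cn(C[C@H](O)[C@H]3OC(=O)C(OCc4ccccc4)=C3OCc3ccccc3)nn2)cc1`, gives 28300 nM in this assay.

Among the measured compounds shown here, compound 2 holds the lowest of the two numbers in this assay; its nearest neighbour is compound 1, and the single measured step, a 2.1-fold lower number from compound 1 to compound 2 (0.33 log units; beyond the scatter), separates them. Compound 3, `O=C1O[C@H]([C@@H](O)Cn2cc(CCO)nn2)C(OCc2ccccc2)=C1OCc1ccccc1`, has not yet been measured. It differs from compound 2 in one place: 2-hydroxyethyl in place of 4-methoxyphenyl on an aromatic carbon.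

For the measured compounds named here, the one measured step bears on this change only loosely. It shows that exchanging one six-membered aromatic ring for another with a different substituent moved the number by a modest amount in this assay. The step to compound 3 goes further, removing the six-membered aromatic ring altogether and putting a short chain with a hydrogen-bond donor in its place. Going by the values given here, with no measured compound lacking an aromatic ring at that position, the direction must be inferred from the size of the group that leaves. Compound 3 is therefore expected to give a higher number, with the step of a 2.1-fold higher number from compound 2 to compound 3 (0.33 log units; beyond the scatter) estimated to be larger than the measured one. The estimate for compound 3 is 60000 nM, within the range 25000 nM to 150000 nM.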

Compound 3, half-maximal inhibitory concentration: > 100000 nM
Compound 3: a limit, no number; the forecaster's own chance of this, stated with the estimate: 25%; middle value at least 1.6-fold (0.22 log units) away from the limit.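

Compound 3 gives only a limit in this assay, not a number: the limit of > 100000 nM in this assay, at which 1 of the 3 values shown sits. Where the earlier pair swapped one substituted phenyl ring for another, this change removes the six-membered aromatic ring from the aromatic carbon altogether, and with 2-hydroxyethyl in place of 4-methoxyphenyl the result is an at least 3.5-fold higher number from compound 2 to compound 3 (0.54 log units; beyond the scatter). Measured against the other aromatic compound, with 2-hydroxyethyl in place of 3-hydroxyphenyl, the result is an at least 1.6-fold higher number from compound 1 to compound 3 (0.22 log units; that floor lies within the scatter), so the position tolerates no clear gain from this chain, and only the comparison with 4-methoxyphenyl shows a loss beyond the scatter.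

The compounds shown leave open whether the higher number goes with the loss of the aromatic ring or with the terminal hydroxyl of the chain, as the two changes arrive together in compound 3, and the limit hides how large either step really is. An unsubstituted phenyl, a 2-methoxyethyl chain or a longer chain ending in an amine at this position would each help to separate these two readings.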